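The source may report more compounds than this note shows. Statements on the series, on what has been measured and on what is new or still open speak of the compounds shown alone.

Compound 1 `COc1ccc(Nc2nc(SCc3cn(Cc4ccccc4Cl)nn3)nc(-c3ccccc3)c2C#N)cc1` is one of three closely related compounds tested in a functional assay on MCF7 cells (Homo sapiens) for inhibition, read by MTT assay, with a stated time of 72 h (on this read-out higher numbers stand for weaker inhibition and lower numbers for stronger inhibition), where compound 1 gives 8050 nM. That is the second highest of the three numbers. Compound 2 `N#Cc1c(Nc2ccccc2Cl)nc(SCc2cn(Cc3ccccc3Cl)nn2)nc1-c1ccccc1` gives 1950 nM, and compound 3 `N#Cc1c(Nc2cccc(Cl)c2)nc(SCc2cn(Cc3ccccc3Cl)nn2)nc1-c1ccccc1` gives 12000 nM. The three differ only in the aryl group carried on a nitrogen on an aromatic ring. Replacing that group gives a 4.1-fold lower number from compound 1 to compound 2 (0.62 log units; beyond the scatter), and a 6.2-fold higher number from compound 2 to compound 3 (0.79 log units; beyond the scatter), while a 1.5-fold higher number from compound 1 to compound 3 (0.17 log units; within the scatter).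

Compound 4 `N#Cc1c(Nc2ccccc2)nc(SCc2cn(Cc3ccccc3Cl)nn2)nc1-c1ccccc1` keeps the shared core of compound 1 and differs from it by hydrogen in place of methoxy on an aromatic carbon. Going by the values given here, no measured pair shows exactly this change; the nearest comparison is compound 1 against compound 3, where exchanging the 4-methoxyphenyl for a 3-chlorophenyl stayed within the scatter, and only compound 2, with its 2-chlorophenyl, moved beyond it. Since removing the methoxy is a smaller alteration than either swap, the expected step of a 1.2-fold lower number from compound 1 to compound 4 (0.06 log units; within the scatter) is small, with no clear direction beyond the scatter. Compound 4 is therefore estimated at 7000 nM in this assay, with a plausible range from 2500 nM to 20000 nM.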

Compound 4, half-maximal inhibitory concentration: > 64000 nM
Compound 4: a limit, no number; the forecaster's own chance of this, stated with the estimate: 5%; middle value at least 9.1-fold (0.96 log units) from the limit.
By their numbers in this assay, from the lowest: compound 2; then compounds 1 and 3 (each within the scatter of the next). At a limit, above all of these: compound 4.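

Compound 4, which carries a plain phenyl where the others carry a substituted ring, gives a limit and not a number: the limit of > 64000 nM in this assay, at which 1 of the 4 values shown sits.

The earlier compounds shown here only compared one substituent with another, and compounds 1 and 3 stayed within the scatter of each other despite carrying different groups, which made this part of the molecule look tolerant of change. Removing the substituent altogether is a different kind of change: hydrogen in place of methoxy gives an at least 7.9-fold higher number from compound 1 to compound 4 (0.90 log units; beyond the scatter) in this series, hydrogen in place of chloro gives an at least 5.3-fold higher number from compound 3 to compound 4 (0.72 log units; beyond the scatter) and the same exchange gives an at least 32-fold higher number from compound 2 to compound 4 (1.51 log units; beyond the scatter) as the largest of the three. Among these four compounds, then, every ring with a substituent gives a measured number and the one ring without a substituent does not, with no compound going against that.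

Going by these compounds, how far compound 4 really lies from the others stays unknown, since a limit sets only a floor on each step. Also open, on these data alone, is whether a different small group on this ring, such as fluoro, methyl, hydroxyl or an amine, would behave like methoxy and chloro or like hydrogen.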